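Methylsulfonyl in Place of an Aryl Carbonyl Group

The source may hold more compounds than are shown below. What is called first, only, known or untested is meant among the compounds shown, and "the series" means these compounds.

Compound 1, `CC(=O)N1N=C(c2ccc(-n3ccnc3)cc2)CC1c1ccc(N(C)C)cc1`: -2.1%
Compound 2, `CN(C)c1ccc(C2CC(c3ccc(-n4ccnc4)cc3)=NN2C(=O)c2ccc(C(F)(F)F)cc2)cc1`: 15.9%

In a functional assay on NCI-H1975 cells (Homo sapiens) for inhibition, read by sulforhodamine B assay, tested at 10 uM (a lower number here means less inhibition, a higher number more inhibition at the concentration tested (going by the name of the read-out)), compound 2 gives 15.9%, the higher of the two numbers shown; compound 1 gives -2.1%. For the measured compounds named here, the only measured step, a number 18 percentage points higher from compound 1 to compound 2 (beyond the scatter), came with a larger group on the carbonyl carbon. Compound 3, `CN(C)c1ccc(C2CC(c3ccc(-n4ccnc4)cc3)=NN2S(C)(=O)=O)cc1`, differs from compound 2 by methylsulfonyl in place of (4-(trifluoromethyl)phenyl)carbonyl on an amine nitrogen in a ring. The new group is small again, and the one step shown suggests that the smaller substituent sits near the level of compound 1. Compound 3 is therefore expected to give about 3%, within -12% to 18%. The expected step is a number 12.9 percentage points lower from compound 2 to compound 3 (beyond the scatter), a fall back toward no inhibition.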

Compound 3, a percentage reported as inhibition, at one concentration (the size of the read-out at that concentration, not a potency): -3.8%
Estimate against measurement, compound 3: 6.8 percentage points above, and the stated range covers the measured number.
By their numbers in this assay, from the lowest: compounds 3 and 1 (each within the scatter of the next); then compound 2.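

At this amine nitrogen in a ring, methylsulfonyl in place of (4-(trifluoromethyl)phenyl)carbonyl gave a number 19.7 percentage points lower from compound 2 to compound 3 (beyond the scatter) in this assay. Methylsulfonyl in place of acetyl gave a number 1.7 percentage points lower from compound 1 to compound 3 (within the scatter), so sulfonyl and carbonyl attachment cannot be told apart when the group carries only methyl, and among these three compounds only compound 2, with its aromatic ring, stands apart. Nothing measured on these compounds explains this result.

Open, on these data alone, is whether 4-(trifluoromethyl)phenylsulfonyl would match compound 2 at this nitrogen. Also open, as far as these compounds go, is whether a plain benzoyl group would do so, which would show what the trifluoromethyl group contributes.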